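The source may hold more compounds than are shown below. What is called first, only, known or untested is meant among the compounds shown, and "the series" means these compounds.

Measured compounds:
compound 1 `CCCCCC(=O)Nc1cc2nc(C3CCCCC3)[nH]c2cc1N1CCCC1` — > 100 ug/mL
compound 2 `CCCOCC(=O)Nc1cc2nc(C3CCCCC3)[nH]c2cc1N1CCCC1` — > 100 ug/mL
compound 3 `CCCOCC(=O)Nc1cc2nc(C3CCCCC3)[nH]c2cc1N(C)C` — < 50 ug/mL

All three were tested in an ADME assay on Vero cells (Chlorocebus sabaeus) for cytotoxicity, read by resazurin assay, with a stated time of 3 days; a lower number here means a stronger inhibitor, a higher number a weaker inhibitor. In this assay compound 1 gives > 100 ug/mL, which is a limit of the assay rather than a number. Compound 2 likewise gives > 100 ug/mL, again only a limit. Compound 3 gives < 50 ug/mL, also a limit, but one at the other end of the range. Two of the three values sit at the limit of > 100 ug/mL in this assay, at which 2 of the 3 values shown sit, and one sits at the limit of < 50 ug/mL in this assay, at which 1 of the 3 values shown sits.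

Compound 1 and compound 2 share a core and differ only in one place: butyl in place of propoxy on a saturated chain carbon bound to a carbonyl carbon. Because both values are limits, the step that the two limits leave unreadable from compound 2 to compound 1 cannot be read. Compound 2 and compound 3 differ in their cores: dimethylamino in place of pyrrolidin-1-yl on an aromatic carbon. Here the step of an at least 2.0-fold lower number from compound 2 to compound 3 (0.30 log units; that floor lies within the scatter) is at least a floor that itself lies within the usual scatter.

Compound 4 `CCCCCC(=O)Nc1cc2nc(C3CCCCC3)[nH]c2cc1N(C)C` has not yet been measured. It stands to compound 3 as compound 1 stands to compound 2: butyl in place of propoxy on a saturated chain carbon bound to a carbonyl carbon. The place of the change is the same in both pairs, so it is the same change, made a second time on the core of compound 3.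

Given that the earlier step that the two limits leave unreadable from compound 2 to compound 1 is unreadable, there is no measured size to carry over, and the expectation for compound 4 rests mainly on the limit of compound 3, < 50 ug/mL. The step from compound 3 to compound 4 is expected to be about a step that the limit leaves unreadable from compound 3 to compound 4. Compound 4 is therefore estimated to give about 30 ug/mL, between 10 ug/mL and 70 ug/mL, in this assay.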

Compound 4, half-maximal inhibitory concentration: > 100 ug/mL
Compound 4 was reported as a limit; the forecaster's own chance of this, stated with the estimate: 40%; middle value at least 3.3-fold (0.52 log units) away from the limit.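

In this assay, butyl in place of propoxy gives an at least 2.0-fold higher number from compound 3 to compound 4 (0.30 log units; that floor lies within the scatter), so this change has only a floor and no measured size. The same change on the core with pyrrolidin-1-yl joins two limits, and that step cannot be read, nor can the step that joins the other two limits, so these compounds do not show whether the change carries from one core to the other with a similar size, or even in the same direction. Compound 4 gives a limit of the assay and not a number: the limit of > 100 ug/mL in this assay, at which 3 of the 4 values shown sit.

What these compounds leave open is how a shorter chain, a longer chain, a carboxylic acid or an amine would read in place of butyl on the saturated chain carbon bound to a carbonyl carbon. Also open, as far as these compounds go, is what piperidin-1-yl or morpholin-4-yl would give on the aromatic carbon in place of dimethylamino or pyrrolidin-1-yl, and whether any such compound would give a true number rather than a limit, which would allow two cores to be compared directly.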